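Smaller Amide Substituent, Expected to Raise Lipophilicity

A few compounds are considered here, and "the series" means these few. Any claim that something is new, unique, unknown or untested is made for them only; others in the source may bear on it.

Compound 2 `CNC(=O)c1cc(C(=O)NCCC[C@H]2OC[C@H](N)CO2)cc2c1OC[C@H]2c1ccccc1` gives 2.6 in a physicochemical assay for lipophilicity, at pH 7.4 (a lower number here means a more polar compound, a higher number a more lipophilic compound), the lowest of the three measured numbers; compound 3 `CNC(=O)c1cc(C(=O)N[C@H]2[C@@H]3COC[C@@H]32)cc2c1OC[C@H]2c1cccc2[nH]ccc12` gives 3.1 and compound 1 `CNC(=O)c1cc(C(=O)N[C@H]2[C@@H]3COC[C@@H]32)cc2c1OC[C@H]2c1cccc(OC)c1` gives 3.2, both beyond the scatter above compound 2. Compound 4 `CNC(=O)c1cc(C(=O)N[C@H]2C[C@@H]2C)cc2c1OC[C@H]2c1ccccc1` differs from compound 2 on the amide nitrogen: a group of 4 heavy atoms (4 carbon; one three-membered non-aromatic ring of carbon only) in place of a group of 10 heavy atoms (7 carbon, 1 nitrogen, 2 oxygen; one six-membered non-aromatic ring with 2 hetero atoms), on an amide-type nitrogen. Among the measured compounds shown here, the only measured step, a number 0.10 log units lower from compound 1 to compound 3 (within the scatter), concerns the group on the saturated ring carbon, not the amide nitrogen, so no step bears directly on this change. Compound 1 at 3.2 and compound 3 at 3.1 also lack the leaving group and both stand above compound 2. An upward step a number 1.00 log units higher from compound 2 to compound 4 (beyond the scatter) beyond the scatter is therefore expected. Compound 4 is estimated at 3.6, with a range from 3 to 4.2.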

Compound 4, distribution coefficient: 4.5
Estimate against measurement, compound 4: 0.90 log units below; the whole stated range lies below it.
By their numbers in this assay, from the lowest: compound 2; then compounds 3 and 1 (each within the scatter of the next); then compound 4.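

On the amide-type nitrogen, the group can move the number in this assay a long way: 2-methylcyclopropyl in place of the larger ring-bearing group gives a number 1.90 log units higher from compound 2 to compound 4 (beyond the scatter), a large step. Among the compounds shown here, the one earlier step, a number 0.10 log units lower from compound 1 to compound 3 (within the scatter), lies at a different place and stays within the scatter. Nothing available here accounts for the size of the new step.

The change alters size, ring, hydrogen-bond donors and acceptors together, so the compounds shown do not separate these features. Where a plain butyl chain on that nitrogen would fall also remains open.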